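Amide-to-urea exchange in a cytotoxicity series

The source may hold more compounds than are shown below. What is called first, only, known or untested is meant among the compounds shown, and "the series" means these compounds.

Compound 1 `COc1cc(-c2nn(-c3cccc(NC(=O)c4cccc(C(F)(F)F)c4)c3)cc2-c2ccncc2)ccc1Cl` carries an amide in which the carbonyl bears a 3-(trifluoromethyl)phenyl group. In a functional assay on IGROV-1 cells (Homo sapiens) for inhibition, read by sulforhodamine B assay, with a stated time of 48 h (on this read-out lower numbers stand for higher toxicity in this test and higher numbers for lower toxicity in this test), compound 1 gives > 50000 nM, which is a limit of the test rather than a measured number. On the numbers shown, compound 1 therefore stands at the top of the range, as the limit of > 50000 nM in this assay, at which 1 of the 2 values shown sits, records. Compound 2 `O=C(Nc1cccc(-n2cc(-c3ccncc3)c(-c3ccc(Cl)c(O)c3)n2)c1)Nc1ccc(Cl)c(Cl)c1` is a urea with a different aryl substitution pattern at both ends of the shared core. In this assay compound 2 gives > 32500 nM, also a limit and not a number, as the limit of > 32500 nM in this assay, at which 1 of the 2 values shown sits, records. For the measured compounds named here, no step between two measured compounds exists here, so no measured change is available for direction or size.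

Compound 3 `COc1cc(-c2nn(-c3cccc(NC(=O)Nc4cccc(C(F)(F)F)c4)c3)cc2-c2ccncc2)ccc1Cl` differs from compound 1 by (3-(trifluoromethyl)phenyl)amino in place of 3-(trifluoromethyl)phenyl on a carbonyl carbon. Given that compound 1 sits at the limit of > 50000 nM in this assay, at which 1 of the 2 values shown sits, and compound 2 at the limit of > 32500 nM in this assay, at which 1 of the 2 values shown sits, compound 3 is expected to stay beyond the working range of this assay. The expected step of a number no higher from compound 1 to compound 3 (the limit leaves the size open) is none beyond the scatter. The estimate for compound 3 in this assay is 50000 nM, with a range of 20000 nM to 120000 nM, most likely reported again only as a limit.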

Compound 3, concentration lethal to 50% of the cells: 50000 nM
Beside the measured number, compound 3's estimate shows no gap at the digits printed, within the range that was stated.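

In this assay, exchanging 3-(trifluoromethyl)phenyl for (3-(trifluoromethyl)phenyl)amino on a carbonyl carbon turns the amide into a urea and gives a number no higher from compound 1 to compound 3 (the limit leaves the size open); the size of this step cannot be read. For the compounds shown here, compound 3 gives 50000 nM, the only value in the set that is a number and not a limit, so this position now has one measured reading, with the urea carrying one added hydrogen-bond donor. The value for compound 1 remains a limit and not a number: the limit of > 50000 nM in this assay, at which 1 of the 3 values shown sits.

On these data alone, how far the exchange moves the read-out stays open: compound 1 offers no number to set against compound 3, and compound 2 differs from compound 3 in more than one place. Also open, as far as these compounds go, is how the series would read in this assay with an aliphatic amine or a longer alkyl chain on the same carbonyl carbon in place of (3-(trifluoromethyl)phenyl)amino.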